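The source may hold more compounds than are shown below. What is called first, only, known or untested is meant among the compounds shown, and "the series" means these compounds.

Measured so far:

- Compound 1 `CCCC(=O)Oc1ccc2oc(/C=C/[S+](C)[O-])cc(=O)c2c1` gives 8700 nM in a functional assay on DLD-1 cells (Homo sapiens) for cytotoxicity, with a stated time of 48 h; a lower number here means a stronger inhibitor, a higher number a weaker inhibitor.
- Compound 3 `CC(C)C(=O)Oc1ccc2oc(/C=C/[S+](C)[O-])cc(=O)c2c1` gives 9100 nM in this assay.
- Compound 2 `C[S+]([O-])/C=C/c1cc(=O)c2cc(C#N)ccc2o1` reaches only the limit > 10000 nM in this assay, so no number is known for it.

Among the two numbers, compound 1 has the lower one, and its nearest neighbour is compound 3, with a 1.0-fold higher number from compound 1 to compound 3 (0.02 log units; within the scatter) separating them. That step swaps the chain on the carbonyl carbon of the ester that sits on the shared core, with isopropyl in place of propyl, and it changed nothing worth noting. Compound 2 carries a cyano group in place of the ester, and an at least 1.1-fold higher number from compound 1 to compound 2 (0.06 log units; that floor lies within the scatter) is all that can be said of it, since it sits at the limit (the limit of > 10000 nM in this assay, at which 1 of the 3 values shown sits).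

Compound 4 `C[S+]([O-])/C=C/c1cc(=O)c2cc(OC(=O)C(C)(C)C)ccc2o1` is yet to be tested. It differs from compound 1 by tert-butyl in place of propyl on a carbonyl carbon. Within the data shown here, the only measured step at the same place is the one from compound 1 to compound 3, which stayed within the scatter. Compound 4 is therefore expected to show a 1.0-fold higher number from compound 1 to compound 4 (0.01 log units; within the scatter), nothing beyond the scatter. Compound 4 is estimated at 9000 nM, with a likely range from 4500 nM to 18000 nM.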

Compound 4, half-maximal inhibitory concentration: 8000 nM
Compound 4: middle estimate off by 1.1-fold (0.05 log units), on the high side, within the range that was stated.
By their numbers in this assay, from the lowest: compounds 4, 1 and 3 (each within the scatter of the next). At a limit, above all of these: compound 2.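

With tert-butyl on the carbonyl carbon, a third chain shape joins propyl and isopropyl, and the number in this assay still does not shift: the change from propyl gives a 1.1-fold lower number from compound 1 to compound 4 (0.04 log units; within the scatter), and the extra methyl on the isopropyl chain gives a 1.1-fold lower number from compound 3 to compound 4 (0.06 log units; within the scatter). Across these three esters, then, branching of the chain makes no difference that can be told from the scatter. The comparison with the cyano group yields only an at least 1.2-fold lower number from compound 2 to compound 4 (0.09 log units; that floor lies within the scatter), and it says little, since compound 2 has a limit rather than a number: the limit of > 10000 nM in this assay, at which 1 of the 4 values shown sits.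

On these data alone, what a much longer chain, a phenyl ring or an amine at the end of the chain would do remains open. As far as these compounds go, whether the ester link itself matters also remains open, and a hydroxyl or an amide in its place would bear on that.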